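Methyl in Place of Hydrogen in an Inactive Series

This account rests on a few compounds, and the source may have more. Where it says the series, first, only, none or still open, it means among the compounds named here.

Compound 1 `COc1ccc(C2(O)SC=C(C)n3c2noc3=O)cc1` gives in a functional assay on A2780 cells (Homo sapiens) for antiproliferative activity, read by MTT assay, with a stated time of 3 days (on this read-out lower numbers stand for stronger inhibition and higher numbers for weaker inhibition), only a limit, > 100000 nM.
Compound 2 `CC1=CSC(O)(c2ccc([N+](=O)[O-])cc2)c2noc(=O)n21` gives in this assay only a limit, > 100000 nM.
Compound 3 `CC1=CSC(O)(c2ccccc2)c2noc(=O)n21` gives in this assay only a limit, > 100000 nM.

All three measured compounds share one core and differ only in the group on the attached benzene ring, and all three sit at the limit of > 100000 nM in this assay, at which 3 of the 3 values shown sit. As a result none of the steps between them can be read: a step that the two limits leave unreadable from compound 1 to compound 2, a step that the two limits leave unreadable from compound 1 to compound 3 and a step that the two limits leave unreadable from compound 2 to compound 3 each run from one limit to another. Compound 3 therefore stands at a limit and nowhere else on the numbers shown; how far beyond that limit it truly lies is unknown.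

Compound 4 `CC1=CSC(O)(c2ccc(C)cc2)c2noc(=O)n21` differs from compound 3 by methyl in place of hydrogen on an aromatic carbon. Among the compounds with values here, no measured step bears directly on this change, and the three steps that exist give no readable size in any direction. Within the data shown here, since every compound of this series so far stays at the limit, compound 4 is expected to do the same, with a step that the limit leaves unreadable from compound 3 to compound 4 as the expected step, meaning none beyond the scatter. The estimate for compound 4 in this assay is 150000 nM, in a range from 30000 nM to 1000000 nM, most likely reported only as a limit.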

Compound 4, half-maximal inhibitory concentration: > 100000 nM
Compound 4: a limit, no number; the forecaster's own chance of this, stated with the estimate: 85%; the middle value lies beyond the limit too.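

The steps from compound 1, compound 2 and compound 3 to compound 4 cannot be read in this assay, because all four stand at the same limit: the limit of > 100000 nM in this assay, at which 4 of the 4 values shown sit.

From the compounds shown here alone, how far beyond that limit each compound truly lies, and whether the group on the benzene ring matters at all, stays open.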